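Aryl variation on the triazole of the shared core

A few compounds are considered here, and "the series" means these few. Any claim that something is new, unique, unknown or untested is made for them only; others in the source may bear on it.

Measured so far:
compound 1 `N#CC1=C(N)Oc2c(N)cc3nc4ccccc4nc3c2C12C(=O)N(Cc1cnnn1-c1ccc([N+](=O)[O-])cc1)c1ccccc12` — > 50000 nM
compound 2 `Cc1ccc(C)c(-n2nncc2CN2C(=O)C3(C(C#N)=C(N)Oc4c(N)cc5nc6ccccc6nc5c43)c3ccccc32)c1` — > 50000 nM

In a functional assay on HepG2 cells (Homo sapiens) for antiproliferative activity, read by MTT assay, with a stated time of 48 h (a lower number here means a stronger inhibitor, a higher number a weaker inhibitor), compound 1 gives no number, only a limit of the assay, > 50000 nM. In this assay compound 2 likewise gives only a limit, > 50000 nM. Among the compounds with values here, both readings sit at the limit of > 50000 nM in this assay, at which 2 of the 2 values shown sit, so the one step available, a step that the two limits leave unreadable from compound 1 to compound 2, has no readable size or direction. Compound 2 therefore stands at the top edge of what this assay reports, alongside compound 1.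

Compound 3 `Cc1cc(C)c(-n2nncc2CN2C(=O)C3(C(C#N)=C(N)Oc4c(N)cc5nc6ccccc6nc5c43)c3ccccc32)c(C)c1` carries 2,4,6-trimethylphenyl in place of 2,5-dimethylphenyl on an aromatic nitrogen. Within the data shown here, no measured step bears on this change in a readable way; the only comparison that exists is between two limits. With nothing to suggest movement, compound 3 is expected to remain at the limit in this assay, and the step that the limit leaves unreadable from compound 2 to compound 3 is estimated to be none beyond the scatter. The estimate for compound 3 is 70000 nM, with a range from 30000 nM to 300000 nM.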

Compound 3, half-maximal inhibitory concentration: 48100 nM
Compound 3: middle estimate off by 1.5-fold (0.16 log units), on the high side; low and high end bracket the measured number.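

Within the data shown here, with 2,4,6-trimethylphenyl on the aromatic nitrogen of the five-membered aromatic ring, compound 3 gives a number in this assay, 48100 nM, the first reading at this position that is not a limit. Two steps can be stated, an at least 1.0-fold lower number from compound 2 to compound 3 (0.01 log units; that floor lies within the scatter) and an at least 1.0-fold lower number from compound 1 to compound 3 (0.01 log units; that floor lies within the scatter), and neither floor goes beyond the scatter, so this change of aryl group shows no effect that can be sized. The step between the two limits stays unreadable, and the readings still gather at one edge of this assay: the limit of > 50000 nM in this assay, at which 2 of the 3 values shown sit.

Going by these compounds, it remains open whether an aryl group carrying an amine or a carboxylic acid, or a longer alkyl chain in place of the aryl ring, would give a number well clear of that edge. Equally open, on these data alone, is how plain phenyl would read.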